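A Methoxy Added to the Phenyl on the Core

A few compounds are considered here, and "the series" means these few. Any claim that something is new, unique, unknown or untested is made for them only; others in the source may bear on it.

Compound 1 `COc1cc(/C=C/C(=O)c2cccc(-n3cc(-c4ccccc4)[nH]c3=O)c2)ccc1O` is the stronger of the two measured compounds in a functional assay on 786-0 cells (Homo sapiens) for inhibition; a higher number here means a weaker inhibitor of growth, a lower number a stronger inhibitor of growth: compound 1 gives 1350 nM, while compound 2 `O=C(/C=C/c1cccc(O)c1)c1cccc(-n2cc(-c3ccccc3)[nH]c2=O)c1` gives 2980 nM. Going by the values given here, the one measured step, a 2.2-fold higher number from compound 1 to compound 2 (0.34 log units; beyond the scatter), alters the hydroxyphenyl end of the chain and touches nothing else.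

Compound 3 `COc1ccc(-c2cn(-c3cccc(C(=O)/C=C/c4ccc(O)c(OC)c4)c3)c(=O)[nH]2)cc1` differs from compound 1 at another place: methoxy in place of hydrogen on an aromatic carbon, the phenyl on the shared core becoming 4-methoxyphenyl. Among the compounds with values here, no measured step bears on this site, so that one step offers no direct guide; it only shows that a change at the far end of the chain moved this assay by a modest amount. With nothing pointing either way, the expected step is a 1.0-fold higher number from compound 1 to compound 3 (0.02 log units; within the scatter), none beyond the scatter, in this assay. Compound 3 is therefore estimated at 1400 nM, with a range from 500 nM to 4000 nM.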

Compound 3, concentration for 50% growth inhibition: 4530 nM
Compound 3: the middle estimate sits 3.2-fold (0.51 log units) below what was measured, and the stated range ends below it.
By their numbers in this assay, from the lowest: compound 1; then compounds 2 and 3 (each within the scatter of the next).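

The phenyl on the shared core, which the earlier pair left untouched, turns out to matter in this assay: methoxy in place of hydrogen on this aromatic carbon gives a modest but real loss of growth inhibition (a 3.4-fold higher number from compound 1 to compound 3 (0.53 log units; beyond the scatter)). In this single pair, the unsubstituted phenyl of compound 1 is therefore preferred to the 4-methoxyphenyl of compound 3. Nothing available explains this step at the core phenyl.

From the compounds shown here alone, whether the loss is specific to methoxy or would follow any group on that carbon remains open; a fluorine, a hydroxyl or an ethoxy there would help separate these possibilities. Going by these compounds, it also remains open whether the same step would hold with the 3-hydroxyphenyl end of compound 2 in place of the 4-hydroxy-3-methoxyphenyl end.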